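From compound 2 to its chloro analogue

The source may hold more compounds than are shown below. What is called first, only, known or untested is meant among the compounds shown, and "the series" means these compounds.

In an ADME assay on the whole organism (Mus musculus) for pharmacokinetics, at a dose of 1 mg/kg by the intravenous route (a higher number here means that more of the compound sits outside the plasma, a lower number that more of the compound stays in the plasma), compound 1 `CN(Cc1ccccc1)S(=O)(=O)c1ccc(NC(=O)NCc2ccncc2)cc1` gives 1.37 L/kg and compound 2 `O=C(NCc1cn[nH]c1)Nc1ccc(S(=O)(=O)c2ccccc2)cc1` gives 1.12 L/kg. These two numbers lie within the scatter of each other, so the data do not separate compound 2 from compound 1. Compound 3 `O=C(NCc1cn[nH]c1)Nc1ccc(S(=O)(=O)c2ccc(Cl)cc2)cc1` is compound 2 with a single change, chloro in place of hydrogen on an aromatic carbon, para to a large group, so that phenyl becomes 4-chlorophenyl: chloro in place of hydrogen on an aromatic carbon. For the measured compounds named here, the two measured compounds differ in more than one place, and the series holds no measured step for this change. With nothing to indicate a larger effect, no shift beyond the scatter is expected in this assay. The expected step is a 1.2-fold higher number from compound 2 to compound 3 (0.06 log units; within the scatter). Compound 3 is estimated at 1.3 L/kg, with an expected range from 0.7 L/kg to 2.3 L/kg.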

Compound 3, volume of distribution: 0.61 L/kg
Beside the measured number, compound 3's estimate is 2.1-fold (0.33 log units) above it; the whole stated range lies above it.
By their numbers in this assay, from the lowest: compounds 3, 2 and 1 (each within the scatter of the next, the first and the last beyond it).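

In this assay, for the compounds shown here, the first measured step at this position reads a 1.8-fold lower number from compound 2 to compound 3 (0.26 log units; within the scatter), so phenyl to 4-chlorophenyl gives a difference that stays inside the usual scatter of the measurement. The earlier pair differed in more than one place and could say nothing about a single substitution on this ring; this pair shows that chloro in place of hydrogen, on the aromatic carbon para to a large group, is not separated from hydrogen by these data. No measured information bears on why the step has this size.

A single substituent at this place leaves open whether a fluoro, a methoxy, an amine or a carboxylic acid would give a step beyond the scatter. Also open, on these data alone, is whether the same chloro change reads alike on the core of compound 1.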